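Trading piperidin-1-yl for pyrrolidin-1-yl on a shared core

The compounds below may be only part of what the source reports. "The series", "measured", "known", "first", "only" and "open" are said of these compounds alone.

In a functional assay on HepG2 cells (Homo sapiens) for cytotoxicity, read by MTT assay, with a stated time of 48 h (on this read-out lower numbers stand for stronger inhibition and higher numbers for weaker inhibition), compound 1 (`CC1=NN(C(=O)COc2ccc(Cl)cc2)C(c2ccccc2O)C1`) is reported as "not active" (no number reported), so it comes without a number. Within the data shown here, compound 2 (`CC1=NN(C(=O)CN2CCCCC2)C(c2ccccc2O)C1`) gives 3020 nM, the only number available here, which leaves it with no measured value to be ranked against. Compound 3 (`CC1=NN(C(=O)CN2CCCC2)C(c2ccccc2O)C1`) keeps the core of compound 2 and alters a single group: pyrrolidin-1-yl in place of piperidin-1-yl on a saturated chain carbon bound to a carbonyl carbon. Among the measured compounds shown here, no measured pair shows what such a swap does, so the expectation rests only on how small the structural change is. In this assay, no shift beyond the usual scatter is expected, and the estimated change is a 1.2-fold higher number from compound 2 to compound 3 (0.06 log units; within the scatter). For compound 3 the expected value is 3500 nM, with an estimated range of 1200 nM to 10000 nM.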

Compound 3, half-maximal inhibitory concentration: 5540 nM
Compound 3: middle estimate off by 1.6-fold (0.20 log units), on the low side; measured number inside the range.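

In this assay, trading piperidin-1-yl for pyrrolidin-1-yl on a saturated chain carbon bound to a carbonyl carbon gives a 1.8-fold higher number from compound 2 to compound 3 (0.26 log units; within the scatter) and so stays within the usual scatter. Among these compounds, this is the only measured pair for this position, and it shows that going from a six-membered to a five-membered non-aromatic ring here leaves the two compounds indistinguishable on this read-out. No measurement at hand offers an explanation for this result.

The compounds shown leave open whether a morpholine ring or an open-chain diethylamine at the same place would also give a number of this size. Compound 1 has no number, so it gives no measured comparison with compound 2 or compound 3.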